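This account rests on a few compounds, and the source may have more. Where it says the series, first, only, none or still open, it means among the compounds named here.

Of the compounds shown here, three that share one core have been tested in an assay on membranes from brain for binding affinity to Lysophosphatidylserine lipase ABHD12 (Mus musculus), read by fluorescence, with a stated time of 20 min, tested at 2 uM; a higher number here means a stronger effect of the compound at the concentration tested, a lower number a weaker effect. Compound 1 `FC(F)(F)c1cnc(N2CCC(NC(=S)Nc3cnc4ccccc4c3)CC2)c(Cl)c1` gives 0% in this assay. Compound 2 `FC(F)(F)c1cnc(N2CCC(NC(=S)N3CCCc4ccccc43)CC2)c(Cl)c1` gives 0% in this assay. Compound 3 `COc1ccc(NC(=S)NC2CCN(c3ncc(C(F)(F)F)cc3Cl)CC2)cn1` gives 0% in this assay, so it stands level with compound 1 and compound 2, with no difference between any of them beyond the scatter.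

The next compound, compound 4 `FC(F)(F)c1cnc(N2CCC(NC(=S)Nc3ccccc3)CC2)c(Cl)c1`, differs from compound 3 in one place: phenyl in place of 6-methoxypyridin-3-yl on an amide-type nitrogen. Among the compounds with values here, two measured steps bear on this exchange. The step of no change at the digits printed from compound 1 to compound 3 (within the scatter) replaced quinolin-3-yl by 6-methoxypyridin-3-yl on that same amide-type nitrogen without any shift. The step of no change at the digits printed from compound 2 to compound 3 (within the scatter) changed the group on the thiocarbonyl carbon, again without any shift. Neither exchange at this end of the molecule moved the read-out, and nothing measured here points to a gain when phenyl enters. The step of no change at the digits printed from compound 3 to compound 4 (within the scatter) is therefore expected to stay within the scatter. Compound 4 is expected to give 0% in this assay, within a range from -8% to 12%.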

Compound 4, a percentage reported as inhibition, at one concentration (the size of the read-out at that concentration, not a potency): 66%
For compound 4 the middle estimate is 66 percentage points below the measured one; the measured number lies above the stated range.
By their numbers in this assay, from the lowest: compounds 1, 2 and 3 (each within the scatter of the next); then compound 4.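

Phenyl in place of 6-methoxypyridin-3-yl on the amide-type nitrogen gives a number 66 percentage points higher from compound 3 to compound 4 (beyond the scatter), and phenyl in place of quinolin-3-yl on that nitrogen gives a number 66 percentage points higher from compound 1 to compound 4 (beyond the scatter). Anilino in place of 1,2,3,4-tetrahydroquinolin-1-yl on the thiocarbonyl carbon gives a number 66 percentage points higher from compound 2 to compound 4 (beyond the scatter). The flat read-out of compounds 1, 2 and 3 therefore did not mean that this end of the molecule was unimportant, since the group placed here can decide whether any inhibition appears at the tested concentration.

On these data alone, it remains open whether the methoxy group or the ring nitrogen of 6-methoxypyridin-3-yl accounts for the gap, which pyridin-3-yl or 4-methoxyphenyl could test, and whether phenyl carrying a fluorine, a chlorine or a methyl group keeps the inhibition. Nothing measured here explains why phenyl stands apart from the other groups.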